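Replacing dimethylamino with methyl in compound 2

The source may hold more compounds than are shown below. What is called first, only, known or untested is meant among the compounds shown, and "the series" means these compounds.

In an ADME assay on HPC cells (Homo sapiens) for cytotoxicity, with a stated time of 24 h (a lower number here means that less compound is tolerated, a higher number that more compound is tolerated), compound 2 `CN(C)c1ccc(/C=C2\CCC/C(=C\c3ccccc3[N+](=O)[O-])C2=O)cc1` gives > 400000 nM and this is a limit of the assay, not a number. Its closest measured relative is compound 1 `O=C1/C(=C/c2ccc(Cl)cc2)CCC/C1=C\c1ccccc1[N+](=O)[O-]` with 400000 nM as a true number. Compound 3 `Cc1ccc(/C=C2\CCC/C(=C\c3ccccc3[N+](=O)[O-])C2=O)cc1` differs from compound 2 by methyl in place of dimethylamino on an aromatic carbon of a six-membered aromatic ring of carbon only (methyl in place of dimethylamino on an aromatic carbon).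

Going by the values given here, only one measured step bears on this change: a number no lower from compound 1 to compound 2 (the limit leaves the size open) when dimethylamino takes the place of chloro on an aromatic carbon. On these data alone, its size stays open, so it offers no amount to carry over, and it shows no fall in the tolerated concentration. No step beyond the usual scatter is therefore expected in this assay for the new change, though this rests on a single comparison. The expected step is a number no higher from compound 2 to compound 3 (the limit leaves the size open) and the assay may again report only a limit. Compound 3 is estimated at 400000 nM with an expected range from 200000 nM to 800000 nM if a number is obtained.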

Compound 3, half-maximal cytotoxic concentration in the HPC assay: > 400000 nM
Compound 3 ended at the assay's limit; the forecaster's own chance of this, stated with the estimate: 55%; the middle value sits exactly at the limit.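

In the HPC assay, methyl joins dimethylamino as a group on this aromatic carbon that leaves the compound at the limit of the assay, and the comparison with the chloro compound gives a number no lower from compound 1 to compound 3 (the limit leaves the size open). The value of compound 3 is a limit and not a number, as is that of compound 2, so the step between them cannot be read, and neither can its size be read in any step that ends at such a limit. The new information lies in a physicochemical assay for lipophilicity (a higher number here means a more lipophilic compound, a lower number a more polar compound), where compound 2 gives 4.8 and compound 3 gives 5.15 and this same change brings a measured difference that did not come with any visible fall in the tolerated concentration: the measured partition coefficient of compound 2, 4.8, and of compound 3, 5.15, a number 0.35 log units higher (beyond the scatter)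

How far any of these compounds lies past the limit stays unknown, and the limit hides most of what this series could show in the HPC assay: the limit of > 400000 nM in the HPC assay, at which 2 of the 3 values shown sit. Whether a carboxylic acid or a primary amine on this aromatic carbon would bring the tolerated concentration down to a readable number remains open.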